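Naphthyl in place of difluorophenyl on compound 1

The source may hold more compounds than are shown below. What is called first, only, known or untested is meant among the compounds shown, and "the series" means these compounds.

Compound 1, with the structure `Cn1cncc1C(OCc1ccc(C#N)cc1-c1cc(F)cc(F)c1)c1ccc(C#N)nc1`, is the stronger of the two measured compounds: in a functional assay on NIH3T3 cells (Mus musculus) (a higher number here means that more compound is needed for the effect, a lower number that less compound is needed), compound 1 gives 25 nM. Compound 2, with the structure `Cn1cncc1C(OCc1ccc(C#N)cc1)c1ccc(C#N)c(-c2cccc3ccccc23)c1`, carries a naphthalen-1-yl group on a different part of the core, and in this assay compound 2 gives 110 nM, a weaker result that lies beyond the scatter of the two numbers. Among the measured compounds shown here, since the two compounds differ in more than one place, their values show only that compound 1 needs less material for the effect.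

Compound 3, with the structure `Cn1cncc1C(OCc1ccc(C#N)cc1-c1cccc2ccccc12)c1ccc(C#N)nc1`, keeps the core of compound 1 and changes it in one place: naphthalen-1-yl in place of 3,5-difluorophenyl on an aromatic carbon. For the measured compounds named here, no measured pair tells how this exchange behaves on this core, so the expectation rests on the two values alone. Because compound 2 gives 110 nM with a naphthalen-1-yl group elsewhere, a modest loss is expected in this assay, estimated as the step of a 2.0-fold higher number from compound 1 to compound 3 (0.30 log units; within the scatter), which may still fall within the scatter. Compound 3 is expected to give 50 nM, with a range from 15 nM to 170 nM.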

Compound 3, half-maximal effective concentration: 46 nM
Compound 3: the middle estimate sits 1.1-fold (0.04 log units) above what was measured; the range from low to high includes it.
By their numbers in this assay, from the lowest: compounds 1 and 3 (each within the scatter of the next); then compound 2.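

Replacing 3,5-difluorophenyl with naphthalen-1-yl on this aromatic carbon, ortho to a large group and meta to a cyano group, gives in this assay a 1.8-fold higher number from compound 1 to compound 3 (0.26 log units; within the scatter), so the change cannot be told apart from repeat-measurement scatter and neither compound can be ranked above the other. Among the compounds shown here, this is the first direct reading at this position: with the rest of the core of compound 1 held fixed, it carries either the fluorinated single ring or the larger, fluorine-free naphthalen-1-yl group with no step beyond the scatter. No independent measurement bears on why the two groups give such similar numbers.

The compounds shown leave open whether this latitude extends beyond aromatic carbon rings, for instance to a morpholine, a longer chain ending in an amine, or a carboxylic acid on the same carbon. They also leave open how an unsubstituted phenyl group would read here, which would be needed to separate the contribution of the fluorine atoms of compound 1 from that of the ring itself.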